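The compounds below may be only part of what the source reports. "The series", "measured", "known", "first", "only" and "open" are said of these compounds alone.

The measured compounds in this study:

Compound 1 `COc1ccc(-c2cccc(C(=O)N(C)C)c2)cc1S(=O)(=O)Nc1cccc(NCCCNC(=O)c2cccc(C)c2)c1` — 103%
Compound 2 `COc1ccc(-c2cccc(C(=O)N(C)C)c2)cc1S(=O)(=O)Nc1cccc(NCC(C)NC(=O)c2cccc(C)c2)c1` — 94%
Compound 3 `COc1ccc(-c2cc(C(=O)N(C)C)ccn2)cc1S(=O)(=O)Nc1cccc(NCCNC(=O)c2cccc(C)c2)c1` — 93%

In a functional assay on CHO-RD-HGA16 cells for agonist activity at Orexin/Hypocretin receptor type 1 (Homo sapiens), read by fluorescence and calcium flux, with a stated time of 30 min (a lower number here means a smaller maximal response, a higher number a larger maximal response), compound 3 stands at the lowest of the three numbers, yet its gaps to compound 2 and to compound 1 both lie within the scatter, so the three values are indistinguishable. Compound 4 `COc1ccc(-c2ccnc(C(=O)N(C)C)c2)cc1S(=O)(=O)Nc1cccc(NCCNC(=O)c2cccc(C)c2)c1` is the next compound, and it differs from compound 3 by 2-(dimethylcarbamoyl)pyridin-4-yl in place of 4-(dimethylcarbamoyl)pyridin-2-yl on an aromatic carbon. For the measured compounds named here, the only measured step, a number 9 percentage points lower from compound 1 to compound 2 (within the scatter), concerns the chain between the two nitrogens rather than the pyridine, and no measured pair touches the pyridine at all. With nothing in the data pointing either way, the expected step is a number 1 percentage points higher from compound 3 to compound 4 (within the scatter), that is, none beyond the scatter. Compound 4 is therefore estimated at 94%, within a range of 80% to 108%.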

Compound 4, largest response reached (Emax), in percent of the reference or control that the assay uses: 101%
Compound 4: middle estimate off by 7 percentage points, on the low side; the range from low to high includes it.
By their numbers in this assay, from the lowest: compounds 3, 2, 4 and 1 (each within the scatter of the next).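

In this assay, the exchange of 4-(dimethylcarbamoyl)pyridin-2-yl for 2-(dimethylcarbamoyl)pyridin-4-yl gives a number 8 percentage points higher from compound 3 to compound 4 (within the scatter). For the compounds shown here, this is the first measured pair to touch this position, para to a methoxy group, and it shows that these two arrangements of the same atoms cannot be told apart by maximal response. No available evidence bears on this result. The compounds shown leave open whether the response would hold with a carboxylic acid or a morpholine amide in place of the dimethylcarbamoyl group.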